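The source may hold more compounds than are shown below. What is called first, only, known or untested is meant among the compounds shown, and "the series" means these compounds.

Measured compounds:
- compound 1, `N#Cc1ccc(C(=O)Nc2ccc3nc(NC(=O)C4CCCCC4)sc3c2)cc1`, 3.3 ug/mL
- compound 2, `O=C(Nc1ccc2nc(NC(=O)C3CCCCC3)sc2c1)c1c(F)cccc1C(F)(F)F`, 0.032 ug/mL

Both compounds were tested in a functional assay on WI-38 VA13 cells (Homo sapiens) for cytotoxicity; a higher number here means that more compound is needed for the effect, a lower number that less compound is needed. Compound 1 gives the higher of the two numbers, 3.3 ug/mL, so more of it is needed for the effect. Compound 2 gives 0.032 ug/mL, a far lower number, and the gap between the two values is well beyond the usual scatter of such measurements. Since these two compounds differ in more than one place, the two values can only be set side by side; they tell nothing about any single change.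

Compound 3, `Cc1[nH][n+](C)c(C)c1C(=O)Nc1ccc2nc(NC(=O)C3CCCCC3)sc2c1`, has not yet been measured. It differs from compound 1 in this way: a group of 8 heavy atoms (6 carbon, 2 nitrogen; one five-membered aromatic ring with 2 hetero atoms) in place of a group of 8 heavy atoms (7 carbon, 1 nitrogen; one six-membered aromatic ring of carbon only), on a carbonyl carbon. Everything else in the shared core is unchanged.

For the measured compounds named here, with no step between measured compounds that isolates a single change, there is no direct guide to what this replacement does. The change is an exchange of one ring type for another of the same size in atoms, at the carbonyl carbon of the amide. The expectation here is a moderate rise in the number, a step of a 2.4-fold higher number from compound 1 to compound 3 (0.38 log units; beyond the scatter), beyond the scatter but not large. For compound 3 in this assay the estimated value is 8 ug/mL, within a range from 1.5 ug/mL to 40 ug/mL.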

Compound 3, half-maximal effective concentration: 0.012 ug/mL
Compound 3: middle estimate off by 670-fold (2.82 log units), on the high side; measured number below the stated range.
By their numbers in this assay, from the lowest: compound 3; then compound 2; then compound 1.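

For the compounds shown here, this is the one step so far that isolates a single change: in this assay, replacing the 4-cyanophenyl group on the carbonyl carbon with a positively charged five-membered aromatic ring gives a 280-fold lower number from compound 1 to compound 3 (2.44 log units; beyond the scatter). The shared core stays the same and the two groups have the same count of heavy atoms, so the number in this assay depends strongly on which group sits at this position, not just on how many heavy atoms it holds. No measurement shown accounts for the size of this step.

The exchange alters several things at once: the ring size, the net charge, the hydrogen-bond donors and acceptors, and the loss of the nitrile, and this single step cannot separate their contributions. A thiophene ring would keep the five-membered ring without the net charge, while an unsubstituted phenyl ring would remove only the nitrile from compound 1, so these two groups would begin to show which part of the exchange goes with the lower number.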